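The source may hold more compounds than are shown below. What is called first, only, known or untested is meant among the compounds shown, and "the series" means these compounds.

Measured so far, all in a functional assay (B cells) with Mus musculus as the target; on this read-out higher numbers stand for an effect only at larger amounts of compound and lower numbers for an effect already at smaller amounts:
compound 1 `C=CCn1c(=O)n(CCCCCCCC)c2nc(N)nc(O)c21` — compound 1 gives 37 uM
compound 2 `Nc1nc(O)c2c(n1)n(C1OC(CO)[C@@H](O)[C@H]1O)c(=O)n2CC(O)CSc1ccccc1` — compound 2 gives 142 uM
compound 3 `C=CCn1c(=S)n(C2OC(COC(C)=O)[C@H]3OC(C)(C)O[C@@H]23)c2nc(N)nc(O)c21` — compound 3 gives 50 uM

Of the three numbers, compound 2 has the highest; its gap to compound 3 and its larger gap to compound 1 both lie beyond the scatter. Compound 4 `NCC(O)Cn1c(=O)n(C2OC(CO)[C@@H](O)[C@H]2O)c2nc(N)nc(O)c21` has not yet been measured in this assay. Compound 4 differs from compound 2 in one place: amino in place of phenylsulfanyl on a saturated chain carbon, two bonds along the chain from an oxygen on a saturated carbon. The phenylsulfanyl group leaves, the amino group enters, both without net charge. For the measured compounds named here, no step between two measured compounds isolates a change of this kind, so nothing measured here fixes its size. The step of a 1.2-fold lower number from compound 2 to compound 4 (0.07 log units; within the scatter) is expected to stay close to the scatter, with no clear direction. Compound 4 is estimated at 120 uM, within 40 uM to 350 uM.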

Compound 4, concentration for half-maximal effect: 28 uM
For compound 4 the middle estimate is 4.3-fold (0.63 log units) above the measured one; the whole stated range lies above it.
By their numbers in this assay, from the lowest: compounds 4, 1 and 3 (each within the scatter of the next); then compound 2.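

In this assay, the saturated chain carbon accepts a drastic swap of amino in place of phenylsulfanyl, giving a 5.1-fold lower number from compound 2 to compound 4 (0.71 log units; beyond the scatter). For this pair, the aromatic ring of the phenylsulfanyl group is therefore not required for the effect. Nothing available explains the size of this step.

Going by these compounds, whether the step reflects the arrival of amino or only the loss of phenylsulfanyl remains open; a dimethylamino group, a carboxylic acid or a benzylsulfanyl group on the same carbon would help separate the two. One pair also cannot show whether the step carries over to other cores.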